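A Nitro Group Added to a Sparingly Soluble Amide

The source may report more compounds than this note shows. Statements on the series, on what has been measured and on what is new or still open speak of the compounds shown alone.

Measured in a physicochemical assay for solubility; on this read-out higher numbers stand for higher solubility and lower numbers for lower solubility:
compound 1 `O=C(Nc1ccccc1)c1cc2cc([N+](=O)[O-])ccc2o1`: 25 ug/mL
compound 2 `COC(=O)c1ccc(NC(=O)c2cc3cc([N+](=O)[O-])ccc3o2)cc1`: 20 ug/mL
compound 3 `NC(=O)c1ccccc1NC(=O)c1cc2ccccc2s1`: < 5 ug/mL

Going by the values given here, the only step between compounds differing in one place is a 1.3-fold lower number from compound 1 to compound 2 (0.10 log units; within the scatter). For compound 3 the value is a limit of the assay, not a number, at the limit of < 5 ug/mL in this assay, at which 1 of the 3 values shown sits. Compound 3 therefore stands beneath every numbered value here. Compound 4 `NC(=O)c1ccccc1NC(=O)c1cc2cc([N+](=O)[O-])ccc2s1` differs from compound 3 by nitro in place of hydrogen on an aromatic carbon. Among the compounds with values here, no measured step covers nitro in place of hydrogen; the one step measured concerns a different group and was small. Compound 4 is expected to remain at or near the limit, with a step that the limit leaves unreadable from compound 3 to compound 4 estimated to lie within the scatter. The estimate for compound 4 is 3 ug/mL, ranging from 1 ug/mL to 8 ug/mL.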

Compound 4, solubility: 10 ug/mL
For compound 4 the middle estimate is 3.3-fold (0.52 log units) below the measured one, outside the stated range (above it).
By their numbers in this assay, from the lowest: compounds 4, 2 and 1 (each within the scatter of the next, the first and the last beyond it). At a limit, below all of these: compound 3.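

In this assay, going by these compounds alone, the first measured step for nitro in place of hydrogen on an aromatic carbon is an at least 2.0-fold higher number from compound 3 to compound 4 (0.30 log units; that floor lies within the scatter) on this core. Compound 3 holds a limit and not a number, so the step has only a floor: the limit of < 5 ug/mL in this assay, at which 1 of the 4 values shown sits. Compound 4 carries a number, so this change does not leave the compound at the limit, though the full size of the step cannot be read.

Going by these compounds, it remains open whether nitro would give a similar step on another core, and how an amine or a carboxylic acid at this position would read in this assay.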